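A few compounds are considered here, and "the series" means these few. Any claim that something is new, unique, unknown or untested is made for them only; others in the source may bear on it.

In a functional assay for inhibition of sodium/hydrogen exchanger (Oryctolagus cuniculus) (a lower number here means a stronger inhibitor, a higher number a weaker inhibitor), compound 3 `Cc1cc(O)c(S(C)(=O)=O)cc1C(=O)N=C(N)N` gives 220 nM and stands highest of the three measured compounds. Compound 1 `Cc1cc(Cl)c(S(C)(=O)=O)cc1C(=O)N=C(N)N` gives 25 nM and compound 2 `Cc1cc(Sc2ccncc2)c(S(C)(=O)=O)cc1C(=O)N=C(N)N` gives 13 nM. The two steps into compound 3 both raised the number: an 8.8-fold higher number from compound 1 to compound 3 (0.94 log units; beyond the scatter) and a 17-fold higher number from compound 2 to compound 3 (1.23 log units; beyond the scatter), so the hydroxy group goes with weaker inhibition. Compound 4 `Cc1cn(-c2cc(C)c(C(=O)N=C(N)N)cc2S(C)(=O)=O)cn1` removes that group: 4-methyl-1H-imidazol-1-yl in place of hydroxy on an aromatic carbon. The nearest measured guide is the step that brought in another ring, a 1.9-fold lower number from compound 1 to compound 2 (0.28 log units; within the scatter), which stayed within the scatter. Compound 4 is therefore expected to return toward the range of compounds 1 and 2, a step of an 8.8-fold lower number from compound 3 to compound 4 (0.94 log units; beyond the scatter). The estimate for compound 4 is 25 nM, between 8 nM and 80 nM.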

Compound 4, half-maximal inhibitory concentration: 28 nM
Compound 4: the middle estimate sits 1.1-fold (0.05 log units) below what was measured, and the stated range covers the measured number.
By their numbers in this assay, from the lowest: compounds 2, 1 and 4 (each within the scatter of the next, the first and the last beyond it); then compound 3.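

Compound 4 shows that this position, ortho to the methylsulfonyl group, accepts a five-membered aromatic ring with no hydrogen-bond donor, with a 7.9-fold lower number from compound 3 to compound 4 (0.90 log units; beyond the scatter). Swapping chloro for this ring leaves the number within the scatter, with a 1.1-fold higher number from compound 1 to compound 4 (0.05 log units; within the scatter), while replacing the (pyridin-4-yl)sulfanyl group costs a little, with a 2.2-fold higher number from compound 2 to compound 4 (0.33 log units; beyond the scatter). No measurement here gives a reason for these differences. On these data alone, it remains open what the methyl on the imidazole ring contributes. Also open, as far as these compounds go, is whether an amine or a carboxylic acid here would behave like the hydroxy group or like the ring groups.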